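Triazole-oxime ether series: aryl swap to pyridin-4-yl

This account rests on a few compounds, and the source may have more. Where it says the series, first, only, none or still open, it means among the compounds named here.

Measured compounds:
compound 1 `COc1cccc(-n2cc(CO/N=C3\CC[C@]4(C)[C@@H](CC/C=C(\C)CC/C=C(\C)CCC=C(C)C)[C@](C)(O)CC[C@H]4C3(C)C)nn2)c1` — 21700 nM
compound 2 `CC(C)=CCC/C(C)=C/CC/C(C)=C/CC[C@@H]1[C@@]2(C)CC/C(=N\OCc3cn(-c4ccc(Cl)cc4)nn3)C(C)(C)[C@@H]2CC[C@@]1(C)O` — 12300 nM

In a functional assay on A549 cells (Homo sapiens) for cytotoxicity, read by MTT assay, with a stated time of 48 h (a higher number here means a weaker inhibitor, a lower number a stronger inhibitor), compound 1 gives 21700 nM, and compound 2 gives 12300 nM. Among the compounds with values here, the single step seen so far, a 1.8-fold lower number from compound 1 to compound 2 (0.25 log units; within the scatter), lies within the scatter, so the two values cannot be ordered; compound 2 is merely the lower of the two numbers, with compound 1 as its only neighbour.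

Compound 3 `CC(C)=CCC/C(C)=C/CC/C(C)=C/CC[C@@H]1[C@@]2(C)CC/C(=N\OCc3cn(-c4ccncc4)nn3)C(C)(C)[C@@H]2CC[C@@]1(C)O` differs from compound 2 by pyridin-4-yl in place of 4-chlorophenyl on an aromatic nitrogen. Within the data shown here, no measured step covers this replacement; the one comparison that exists, a 1.8-fold lower number from compound 1 to compound 2 (0.25 log units; within the scatter), shows that exchanging one aryl group on the same aromatic nitrogen for another left this assay unmoved beyond the scatter. On that basis no step beyond the scatter is expected for compound 3 either, and the estimated step of a 1.2-fold higher number from compound 2 to compound 3 (0.09 log units; within the scatter) is close to nil. Compound 3 is therefore expected to give about 15000 nM in this assay, with a range from 6000 nM to 40000 nM.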

Compound 3, half-maximal inhibitory concentration: 13000 nM
Beside the measured number, compound 3's estimate is 1.2-fold (0.06 log units) above it, within the range that was stated.
By their numbers in this assay, from the lowest: compounds 2, 3 and 1 (each within the scatter of the next).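

In this assay the step of a 1.1-fold higher number from compound 2 to compound 3 (0.02 log units; within the scatter) and the step of a 1.7-fold lower number from compound 1 to compound 3 (0.22 log units; within the scatter) extend the comparison at this position from aryl rings of carbon only to a six-membered aromatic ring with 1 hetero atom and 1 hydrogen-bond acceptor. A ring nitrogen in the aryl group on the aromatic nitrogen therefore gives no step beyond the scatter, and compound 1, compound 2 and compound 3 cannot be ordered. No measurement shown here accounts for this flat reading.

Still open, on these data alone, is whether anything other than a six-membered aromatic ring on this aromatic nitrogen would give a step beyond the scatter. An aliphatic amine, a carboxylic acid or a longer chain at this place would test that.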